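A Hydroxymethyl on the Indole Nitrogen of Compound 2

The source may hold more compounds than are shown below. What is called first, only, known or untested is meant among the compounds shown, and "the series" means these compounds.

Compound 1, `COc1ccc(-c2cc3nccc(-c4cc(OC)c(OC)c(OC)c4)n3n2)cc1F`, gives 183 nM in a functional assay on MCF7 cells (Homo sapiens) for inhibition, read by CCK-8 assay, with a stated time of 48 h; a lower number here means a stronger inhibitor, a higher number a weaker inhibitor.
Compound 2, `COc1cc(-c2ccnc3cc(-c4c[nH]c5ccccc45)nn23)cc(OC)c1OC`, gives 85 nM in this assay.
Compound 3, `COc1cc(-c2ccnc3cc(-c4ccc5c(ccn5C)c4)nn23)cc(OC)c1OC`, gives 3 nM in this assay.

Compound 2 holds the second highest of the three numbers: there is a 2.2-fold lower number from compound 1 to compound 2 (0.33 log units; beyond the scatter), while there is a 28-fold lower number from compound 2 to compound 3 (1.45 log units; beyond the scatter).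

Compound 4, `COc1cc(-c2ccnc3cc(-c4cn(CO)c5ccccc45)nn23)cc(OC)c1OC`, differs from compound 2 by hydroxymethyl in place of hydrogen on an aromatic nitrogen. Going by the values given here, no measured step changes only the group on that aromatic nitrogen. The step of a 28-fold lower number from compound 2 to compound 3 (1.45 log units; beyond the scatter) does add a methyl there, but the names 1H-indol-3-yl and 1-methyl-1H-indol-5-yl show that the ring atom carrying the link changes as well, so that step gives no clean guide. With no direct comparison, a step within the scatter is expected in this assay. Compound 4 is estimated at 70 nM, between 25 nM and 200 nM. This expected result means a 1.2-fold lower number from compound 2 to compound 4 (0.08 log units; within the scatter).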

Compound 4, half-maximal inhibitory concentration: 19 nM
For compound 4 the middle estimate is 3.7-fold (0.57 log units) above the measured one; the whole stated range lies above it.
By their numbers in this assay, from the lowest: compound 3; then compound 4; then compound 2; then compound 1.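

Going by these compounds alone, this pair is the first to change only the group on the aromatic nitrogen, and in this assay hydroxymethyl in place of hydrogen gives a 4.5-fold lower number from compound 2 to compound 4 (0.65 log units; beyond the scatter). The hydrogen on this nitrogen is therefore not needed for activity here, and a group of 2 heavy atoms can sit there while the number still falls. Nothing shown explains why the number falls.

As far as these compounds go, it remains open whether a longer chain such as hydroxyethyl, or an aminomethyl group, on this nitrogen of compound 2 would lower the number further or raise it. A plain methyl there would help show whether the oxygen of hydroxymethyl matters.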